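A Saturated Amine Arm Replaces the Pyridine Arm

The source may report more compounds than this note shows. Statements on the series, on what has been measured and on what is new or still open speak of the compounds shown alone.

The three measured compounds share one core and differ only in the group carried on the aromatic nitrogen. Compound 1 `CCN(Cc1cccnc1)c1ccc(C(=O)N2CCc3ccc(OS(N)(=O)=O)cc3C2)cc1` gives 35.7% in an assay on HEK293 cells for inhibition of Steryl-sulfatase (Homo sapiens), tested at 0.1 uM; on this read-out lower numbers stand for a weaker effect and higher numbers for a stronger effect at the one concentration tested. Compound 2 `CCN(Cc1ccccn1)c1ccc(C(=O)N2CCc3ccc(OS(N)(=O)=O)cc3C2)cc1` gives 42.5% in this assay, and compound 3 `CCN(Cc1ccncc1)c1ccc(C(=O)N2CCc3ccc(OS(N)(=O)=O)cc3C2)cc1` gives 47%. Compound 3 holds the highest of the three numbers: a number 11.3 percentage points higher from compound 1 to compound 3 (beyond the scatter), whereas a number 6.8 percentage points higher from compound 1 to compound 2 (within the scatter) and a number 4.5 percentage points higher from compound 2 to compound 3 (within the scatter).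

Compound 4 `CN(CCN1CCCCC1)c1ccc(C(=O)N2CCc3ccc(OS(N)(=O)=O)cc3C2)cc1` differs from compound 3 in one place: methyl(2-(piperidin-1-yl)ethyl)amino in place of ethyl((pyridin-4-yl)methyl)amino on an aromatic carbon. Among the compounds with values here, none of the measured steps bears directly on this change; each of them only moves the ring nitrogen within a pyridinyl group, and only the step from compound 1 to compound 3 reaches beyond the scatter. The exchange of an aromatic ring for a non-aromatic one, joined through a longer chain, is not covered by any measured pair, so no direction can be read from the data. The number for compound 4 is therefore expected to sit near the middle of the measured spread, a number 7 percentage points lower from compound 3 to compound 4 (within the scatter), with a wide range. Compound 4 is estimated at 40%, between 20% and 60%.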

Compound 4, a percentage reported as inhibition, at one concentration (the size of the read-out at that concentration, not a potency): 0.3%
Compound 4: middle estimate off by 39.7 percentage points, on the high side; the whole stated range lies above it.
By their numbers in this assay, from the lowest: compound 4; then compounds 1, 2 and 3 (each within the scatter of the next, the first and the last beyond it).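

Swapping the arm on the aromatic carbon removes almost all of the effect in this assay: a number 46.7 percentage points lower from compound 3 to compound 4 (beyond the scatter), a number 42.2 percentage points lower from compound 2 to compound 4 (beyond the scatter) and a number 35.4 percentage points lower from compound 1 to compound 4 (beyond the scatter). Moving the ring nitrogen within the pyridinyl group had shifted the number only modestly at most, whereas this change shows that the position does not accept every arm, even though both groups have the same computed heavy-atom, donor and acceptor counts and no net charge. No measurement at hand explains this loss.

The exchange alters the ring, the chain and the small alkyl group on the nitrogen at once, so the compounds shown do not say which of these matters. On these data alone, it remains open whether a phenyl ring in place of the piperidine on the same chain, or a piperidinylmethyl arm with the ethyl group kept, would retain the effect.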